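The source may hold more compounds than are shown below. What is called first, only, known or untested is meant among the compounds shown, and "the series" means these compounds.

Working notes on the series. Compound 3 `COc1ccc(C2=NN(c3ccccc3)C(c3ccc(C)cc3)C2S(=O)(=O)CC2=NCCS2)cc1` and compound 1 `COc1ccc(C2=NN(c3ccccc3)C(c3ccc(C)cc3)C2S(=O)(=O)CC2=NCCO2)cc1` share one core; in a functional assay, tested at 100 ug/mL (a lower number here means a weaker effect, a higher number a stronger effect of the compound at the concentration tested), compound 3 gives 47.9% and compound 1 gives 67.7%, so the step of a number 19.8 percentage points higher from compound 3 to compound 1 (beyond the scatter) comes from the change (a group of 5 heavy atoms (3 carbon, 1 nitrogen, 1 oxygen; one five-membered non-aromatic ring with 2 hetero atoms) in place of a group of 5 heavy atoms (3 carbon, 1 nitrogen, 1 sulfur; one five-membered non-aromatic ring with 2 hetero atoms), on a saturated chain carbon bound to a sulfonyl sulfur). Compound 2 `COc1ccc(-c2nn(-c3ccccc3)c(-c3ccc(C)cc3)c2S(=O)(=O)CC2=NCCS2)cc1` carries a different core, and the difference between the two cores is not broken down here; in this assay compound 2 gives "not active" (no number reported), with no number given. Compound 4 `COc1ccc(-c2nn(-c3ccccc3)c(-c3ccc(C)cc3)c2S(=O)(=O)CC2=NCCO2)cc1` is the unmeasured partner of compound 2, made by the same kind of change, (a group of 5 heavy atoms (3 carbon, 1 nitrogen, 1 oxygen; one five-membered non-aromatic ring with 2 hetero atoms) in place of a group of 5 heavy atoms (3 carbon, 1 nitrogen, 1 sulfur; one five-membered non-aromatic ring with 2 hetero atoms), on a saturated chain carbon bound to a sulfonyl sulfur), at the same kind of place. Compound 4 is expected to gain on compound 2 in this assay by a step similar to that from compound 3 to compound 1, because that step was a number 19.8 percentage points higher from compound 3 to compound 1 (beyond the scatter); as compound 2 has no number to start from, the estimate for compound 4 rests on a weak base and is put at 20%, within 0% to 45%.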

Compound 4, a percentage reported as activity, at one concentration (the size of the read-out at that concentration, not a potency): 72.5%
Compound 4: the middle estimate sits 52.5 percentage points below what was measured; measured number above the stated range.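

Among the compounds shown here, compound 2 has no number in this assay and no step from it to compound 4 can be read. The compounds shown leave open how large the ring change is on the core of compound 4, and no evidence at hand bears on this result.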